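Compound 4 extends the series from compound 3

The source may report more compounds than this note shows. Statements on the series, on what has been measured and on what is new or still open speak of the compounds shown alone.

Of the compounds shown here, three have been measured so far. In an assay on HL-60 cells for agonist activity at vitamin D3 receptor (Homo sapiens), read by microscopy, with a stated time of 96 h (a higher number here means that more compound is needed for the effect, a lower number that less compound is needed), compound 1 `C#CC(C)OC(=O)c1ccc(C(CC)(CC)c2ccc(OCC(=O)C(C)(C)C)c(C)c2)n1CC` gives 210 nM, compound 2 `CCn1c(C(=O)NCCCN(C)C)ccc1C(CC)(CC)c1ccc(OCC(O)C(C)(C)C)c(C)c1` gives 37 nM, and compound 3 `C#CC(C)OC(=O)c1ccc(C(CC)(CC)c2ccc(OCC(O)C(C)(C)C)c(C)c2)n1CC` gives 200 nM. Compound 3 thus stands second highest of the three: a 1.1-fold lower number from compound 1 to compound 3 (0.02 log units; within the scatter), whereas a 5.4-fold higher number from compound 2 to compound 3 (0.73 log units; beyond the scatter). Compound 4 `CCn1c(C(=O)OCc2ccc(F)cc2)ccc1C(CC)(CC)c1ccc(OCC(O)C(C)(C)C)c(C)c1` differs from compound 3 in one place: 4-fluorobenzyl in place of 1-methylprop-2-yn-1-yl on an oxygen next to a carbonyl group. Of the measured steps only a 5.4-fold higher number from compound 2 to compound 3 (0.73 log units; beyond the scatter) touches this position, and it replaced (3-(dimethylamino)propyl)amino with (1-methylprop-2-yn-1-yl)oxy; compound 4 keeps an oxygen on the carbonyl carbon and alters only the group upon it. A smaller shift than that is therefore expected in this assay, a 1.3-fold lower number from compound 3 to compound 4 (0.12 log units; within the scatter), and compound 4 is estimated at 150 nM with a range of 50 nM to 500 nM.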

Compound 4, half-maximal effective concentration: > 50000 nM
Compound 4: only a limit was reported (the forecaster's own chance of this, stated with the estimate: 5%); middle value at least 330-fold (2.52 log units) from the limit.
By their numbers in this assay, from the lowest: compound 2; then compounds 3 and 1 (each within the scatter of the next). At a limit, above all of these: compound 4.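

Compound 4 is reported in this assay only as a limit: the limit of > 50000 nM in this assay, at which 1 of the 4 values shown sits. The group on this oxygen alone can therefore decide the outcome, since 4-fluorobenzyl in place of 1-methylprop-2-yn-1-yl gives an at least 250-fold higher number from compound 3 to compound 4 (2.39 log units; beyond the scatter), a large step where the earlier compounds had shown only a modest one at this carbonyl. Against (3-(dimethylamino)propyl)amino, (4-fluorobenzyl)oxy gives an at least 1300-fold higher number from compound 2 to compound 4 (3.13 log units; beyond the scatter).

The compounds shown leave open whether the fluorine or the aromatic ring carries this step. A plain benzyl or a simple ethyl group on this oxygen would separate the two.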